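This account rests on a few compounds, and the source may have more. Where it says the series, first, only, none or still open, it means among the compounds named here.

Measured so far in a functional assay on NCI-H1975 cells (Homo sapiens) for antiproliferative activity, read by MTT assay, with a stated time of 72 h; on this read-out lower numbers stand for stronger inhibition and higher numbers for weaker inhibition:
- compound 1 `COc1cc2ncnc(Nc3ccc(Cl)c(C(F)(F)F)c3)c2cc1OCCCCC(=O)Nc1ccc(S(N)(=O)=O)cc1`: 3220 nM
- compound 2 `C#Cc1cccc(Nc2ncnc3cc(OC)c(OCCCCC(=O)Nc4ccc(S(N)(=O)=O)cc4)cc23)c1`: 18800 nM

Among the measured compounds shown here, compound 2 stands highest of the two numbers in this assay; its nearest neighbour is compound 1, and the only step measured, a 5.8-fold higher number from compound 1 to compound 2 (0.77 log units; beyond the scatter), separates them. For the measured compounds named here, that step swaps the whole anilino aryl group and is the only guide to how this position behaves.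

Compound 3 `COc1cc2ncnc(Nc3cccc(Br)c3)c2cc1OCCCCC(=O)Nc1ccc(S(N)(=O)=O)cc1` is not yet measured. It differs from compound 2 by bromo in place of ethynyl on an aromatic carbon. Going by the values given here, no measured step exchanges these two groups directly. Among the compounds with values here, the one step that bears on the position, a 5.8-fold higher number from compound 1 to compound 2 (0.77 log units; beyond the scatter), shows that a halogen-bearing aryl ring on the anilino nitrogen gave the lower number, while the ethynyl-bearing ring gave the higher one. Bromo returns a halogen to this ring, so a move back toward compound 1 in this assay seems plausible, though the 4-chloro group of compound 1 is absent and the size of the effect is uncertain.

The expectation for compound 3 is therefore a modest lowering, a 2.1-fold lower number from compound 2 to compound 3 (0.32 log units; beyond the scatter). Compound 3 is estimated at 9000 nM in this assay, with a range from 3000 nM to 25000 nM.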

Compound 3, half-maximal inhibitory concentration: 11400 nM
Beside the measured number, compound 3's estimate is 1.3-fold (0.10 log units) below it, within the range that was stated.
By their numbers in this assay, from the lowest: compound 1; then compounds 3 and 2 (each within the scatter of the next).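

In this assay, bromo in place of ethynyl on the aromatic carbon gives a 1.6-fold lower number from compound 2 to compound 3 (0.22 log units; within the scatter), so compound 2 and compound 3 cannot be separated at this position, and a single halogen on this ring does not by itself reach the number of compound 1. The change from the 4-chloro-3-(trifluoromethyl)phenyl group of compound 1 to the 3-bromophenyl group gives a 3.5-fold higher number from compound 1 to compound 3 (0.55 log units; beyond the scatter), a gap that remains beyond the scatter and is about the same kind of step as that seen with the ethynyl ring, so the advantage of compound 1 belongs to its whole aryl group rather than to the presence of a halogen alone. No measurement bears on why either step has the size it has.

From the compounds shown here alone, it remains open how much of the advantage of compound 1 lies with the 4-chloro group and how much with the trifluoromethyl group, which a 3-(trifluoromethyl)phenyl or a 4-chlorophenyl group on the same nitrogen would separate. The tail is also unexplored, since all three compounds share the same chain and sulfonamide, and a shorter chain or a carboxylic acid in place of the sulfonamide could show whether the numbers move more there than on the aryl ring.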